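The source may report more compounds than this note shows. Statements on the series, on what has been measured and on what is new or still open speak of the compounds shown alone.

In a functional assay on HCC827 cells (Homo sapiens) for antiproliferative activity, read by MTT assay, with a stated time of 72 h (on this read-out lower numbers stand for stronger inhibition and higher numbers for weaker inhibition), compound 1 `CNC(=O)CN1CC[C@H](n2c(Nc3ccccc3)nc3cnc(Nc4ccc(N5CCN(C)CC5)cc4)nc32)C1` gives 170 nM, compound 3 `CN1CCN(c2ccc(Nc3ncc4nc(Nc5ccccc5)n([C@H]5CCN(S(=O)(=O)C6CC6)C5)c4n3)cc2)CC1` gives 1.6 nM, and compound 2 `CN1CCN(c2ccc(Nc3ncc4nc(Nc5ccc(F)cc5)n([C@H]5CCCN(S(=O)(=O)C6CC6)C5)c4n3)cc2)CC1` gives 8.6 nM, the second highest of the three numbers, nearer to compound 3 than to compound 1. Among the compounds with values here, the only single-point step known here, in which cyclopropylsulfonyl replaced (methylcarbamoyl)methyl on an amine nitrogen in a ring, gave a 110-fold lower number from compound 1 to compound 3 (2.03 log units; beyond the scatter). Compound 4 `CCOC(=O)CN1CC[C@H](n2c(Nc3ccc(F)cc3)nc3cnc(Nc4ccc(N5CCN(C)CC5)cc4)nc32)C1` differs from compound 2 by 1-((ethoxycarbonyl)methyl)pyrrolidin-3-yl in place of 1-(cyclopropylsulfonyl)piperidin-3-yl on an aromatic nitrogen. That change takes the cyclopropylsulfonyl group away and brings in 1-((ethoxycarbonyl)methyl)pyrrolidin-3-yl, close to the reverse of the earlier step, so a large rise in the number is expected for compound 4, a 47-fold higher number from compound 2 to compound 4 (1.67 log units; beyond the scatter). The estimate for compound 4 is 400 nM, within a range from 80 nM to 2000 nM.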

Compound 4, half-maximal inhibitory concentration: 1810 nM
Estimate against measurement, compound 4: 4.5-fold (0.66 log units) below, within the range that was stated.
By their numbers in this assay, from the lowest: compound 3; then compound 2; then compound 1; then compound 4.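

The step of a 210-fold higher number from compound 2 to compound 4 (2.32 log units; beyond the scatter) shows that a large change at this aromatic nitrogen also occurs with a (4-fluorophenyl)amino group on both compounds, so the earlier large step was not a one-off. Here, though, the ring size and the group on the ring nitrogen change together. Nothing shown gives a reason for the size of this step. The compounds leave open how much of the step belongs to the ring and how much to the group. A methylsulfonyl group or a carboxylic acid in place of the ester also remains an open case.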